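This account rests on a few compounds, and the source may have more. Where it says the series, first, only, none or still open, it means among the compounds named here.

Working notes on the series. The parent, compound 1 `O=C(NO)c1noc(-c2ccccc2)n1`, gives 112 nM in an assay on isolated protein for inhibition of protein deacetylase HDAC6 (Homo sapiens), read by fluorescence, with a stated time of 90 min; a higher number here means a weaker inhibitor, a lower number a stronger inhibitor. Compound 2 `O=C(NO)c1noc(-c2ccc(Br)cc2)n1` carries bromo in place of hydrogen on an aromatic carbon and in this assay compound 2 gives 2770 nM; the step of a 25-fold higher number from compound 1 to compound 2 (1.39 log units; beyond the scatter) is large. Within the data shown here, of the two numbers so far, compound 2 stands highest, its nearest neighbour being compound 1 with a far lower number.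

Compound 3 `O=C(NO)c1noc(-c2ccc(-c3ccccc3)cc2)n1` is not yet measured. Relative to compound 2 the change is phenyl in place of bromo on an aromatic carbon. Among the measured compounds shown here, only one measured step touches the same position: a 25-fold higher number from compound 1 to compound 2 (1.39 log units; beyond the scatter), which shows that placing a substituent there weakened inhibition substantially. For the measured compounds named here, no step shows how phenyl compares with bromo at that carbon, so the direction is open; a change of moderate size in this assay is expected, with the number for compound 3 estimated to stay nearer compound 2 than compound 1, a 1.5-fold lower number from compound 2 to compound 3 (0.19 log units; within the scatter). The estimate for compound 3 is 1800 nM, with a range from 350 nM to 9000 nM.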

Compound 3, half-maximal inhibitory concentration: 1310 nM
Beside the measured number, compound 3's estimate is 1.4-fold (0.14 log units) above it, within the range that was stated.
By their numbers in this assay, from the lowest: compound 1; then compound 3; then compound 2.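

In this assay, phenyl is a second substituent on this aromatic carbon that leaves the number well above that of the parent, with a 12-fold higher number from compound 1 to compound 3 (1.07 log units; beyond the scatter) as the change. The loss seen with bromo is therefore not unique to that group, and the larger group, with its six-membered aromatic ring of carbon only, does not deepen it: the swap gives a 2.1-fold lower number from compound 2 to compound 3 (0.33 log units; beyond the scatter) and so recovers a modest part of the loss. No measurement available here bears on why these two substituents differ.

On these data alone, whether any group at this carbon can match or improve on the unsubstituted parent remains open. An amine, a carboxylic acid or a methoxy group could show whether the loss holds beyond bromo and phenyl.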